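This account rests on a few compounds, and the source may have more. Where it says the series, first, only, none or still open, it means among the compounds named here.

In a functional assay on A549 cells (Homo sapiens) for cytotoxicity, read by CCK-8 assay, with a stated time of 72 h (a higher number here means a weaker inhibitor, a lower number a stronger inhibitor), compound 2 `C=CCn1c(=O)/c(=C\c2cccc(Br)c2)[nH]c(=O)/c1=C\c1ccccc1OC` gives 5400 nM, and compound 1 `C=CCn1c(=O)/c(=C\c2ccccc2Cl)[nH]c(=O)/c1=C\c1ccccc1OC` gives 5300 nM, the two lying within the scatter of each other. Compound 3 `C=CCn1c(=O)/c(=C\c2ccccc2C(F)(F)F)[nH]c(=O)/c1=C\c1ccccc1OC` differs from compound 2 by 2-(trifluoromethyl)phenyl in place of 3-bromophenyl on a double-bonded chain carbon bound to an aromatic carbon. Among the compounds with values here, the only measured step that bears on this, a 1.0-fold higher number from compound 1 to compound 2 (0.01 log units; within the scatter), exchanged one substituted phenyl for another at the same place with no shift beyond the scatter. Because a 1.0-fold higher number from compound 1 to compound 2 (0.01 log units; within the scatter) was flat, compound 3 is expected to remain close to compound 2, no change at the digits printed from compound 2 to compound 3 (within the scatter). The estimate for compound 3 in this assay is 5400 nM, with a range from 2400 nM to 12000 nM.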

Compound 3, half-maximal inhibitory concentration: 7000 nM
For compound 3 the middle estimate is 1.3-fold (0.11 log units) below the measured one, within the range that was stated.
By their numbers in this assay, from the lowest: compounds 1, 2 and 3 (each within the scatter of the next).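

In this assay, a third substituted phenyl on a double-bonded chain carbon bound to an aromatic carbon again produces no shift beyond the scatter, with a 1.3-fold higher number from compound 2 to compound 3 (0.11 log units; within the scatter). Trifluoromethyl in place of chloro on an aromatic carbon, a change of the substituent alone, is likewise flat, with a 1.3-fold higher number from compound 1 to compound 3 (0.12 log units; within the scatter). Nothing available explains this flatness. The phenyl groups shown carry only chloro, bromo or trifluoromethyl, so whether an amine or a carboxylic acid at this place would move the number beyond the scatter remains open.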